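This account rests on a few compounds, and the source may have more. Where it says the series, first, only, none or still open, it means among the compounds named here.

Measured in a functional assay on T47D cells (Homo sapiens) for antiproliferative activity, read by CCK-8 assay, with a stated time of 72 h; on this read-out lower numbers stand for stronger inhibition and higher numbers for weaker inhibition:

- Compound 1 `COc1ccc(C2CC(c3ccccc3)=NN2C(=O)c2ccco2)cc1`: 27300 nM
- Compound 2 `COc1ccccc1C1=NN(C(=O)c2ccncc2)C(c2ccc([N+](=O)[O-])cc2)C1`: > 50000 nM (a limit, not a number)

Compound 1 gives a real number, though a weak one on this scale. Compound 2 has no exact value and stands only at a limit, as the limit of > 50000 nM in this assay, at which 1 of the 2 values shown sits. Its true position in this assay is therefore unknown, and any step starting from it can only be sized roughly.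

The next compound is compound 3 `COc1ccccc1C1=NN(C(=O)c2ccc([N+](=O)[O-])o2)C(c2ccc([N+](=O)[O-])cc2)C1`. It keeps the rest of compound 2 and changes one group, with 5-nitrofuran-2-yl in place of pyridin-4-yl on a carbonyl carbon. Compound 1 also has a five-membered aromatic ring on its carbonyl and reaches a measurable 27300 nM, although it differs from compound 3 elsewhere too. This is thin support for expecting a measurable number here, and the outcome could still be another limit. The expected change is a modest one toward stronger inhibition, estimated as an at least 3.3-fold lower number from compound 2 to compound 3 (0.52 log units; beyond the scatter). For compound 3 the expected value is 15000 nM, with an estimated range from 3000 nM to 50000 nM.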

Compound 3, half-maximal inhibitory concentration: > 50000 nM
Compound 3: a limit, no number; the forecaster's own chance of this, stated with the estimate: 25%; at least 3.3-fold (0.52 log units) between middle value and limit.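

In this assay compound 3 gives > 50000 nM, which is a limit and not a number. Compound 2 also stands only at a limit, so no step can be read between compound 2 and compound 3. The compounds shown leave open whether 5-nitrofuran-2-yl or pyridin-4-yl on the carbonyl gives stronger inhibition.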